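The source may hold more compounds than are shown below. What is called first, only, known or untested is meant among the compounds shown, and "the series" means these compounds.

Three compounds share one core and differ only in the group that sits on the carbonyl carbon of the amide. Compound 1 `COc1ccc(-c2cnc(NC(=O)c3ccn[nH]3)n2C)cc1` carries 1H-pyrazol-5-yl there, compound 2 `COc1ccc(-c2cnc(NC(=O)c3ccccc3C)n2C)cc1` carries 2-methylphenyl, and compound 3 `COc1ccc(-c2cnc(NC(=O)c3ccc(C#N)cc3)n2C)cc1` carries 4-cyanophenyl. In a toxicity assay on THP-1 cells (Homo sapiens) for inhibition (on this read-out higher numbers stand for lower toxicity in this test and lower numbers for higher toxicity in this test), compound 1 gives > 100000 nM, which is a limit of the assay and not a number. In this assay compound 2 likewise reaches only the limit > 100000 nM. In this assay compound 3 also stands at the limit > 100000 nM, so its place among the three is known only as a limit, not as a number. Because (the limit of > 100000 nM in this assay, at which 3 of the 3 values shown sit), the steps a step that the two limits leave unreadable from compound 1 to compound 2, a step that the two limits leave unreadable from compound 1 to compound 3 and a step that the two limits leave unreadable from compound 2 to compound 3 cannot be read in size or direction.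

Compound 4 `COc1ccc(-c2cnc(NC(=O)c3cccc(O)c3)n2C)cc1` has not yet been measured. Its change from compound 3 is 3-hydroxyphenyl in place of 4-cyanophenyl on a carbonyl carbon. The three measured steps bear on it, since each of them also swaps the group on the carbonyl carbon, but none of them yields a readable size, so no step beyond the scatter can be expected in this assay in either direction. Compound 4 is therefore estimated at 150000 nM, between 60000 nM and 400000 nM, most likely again as a limit. The expected step is a step that the limit leaves unreadable from compound 3 to compound 4.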

Compound 4, half-maximal cytotoxic concentration: > 100000 nM
Compound 4: a limit, no number; the forecaster's own chance of this, stated with the estimate: 85%; the middle value is on the limit's open side.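

No new step can be read: the steps linking compound 4 with compound 1, compound 2 and compound 3 stay unreadable in size and direction, because every value rests on the same limit: the limit of > 100000 nM in this assay, at which 4 of the 4 values shown sit. The compounds shown leave open whether the groups on the carbonyl carbon differ from one another at all in this assay.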